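Dimethoxyphenyl exchange repeated on a second pyridinyl core

The source may report more compounds than this note shows. Statements on the series, on what has been measured and on what is new or still open speak of the compounds shown alone.

Compound 1 `COc1ccc(OC)c(C(=O)/C=C/c2cn(-c3ccccc3)nc2-c2cccnc2)c1` and compound 2 `COc1ccc(C(=O)/C=C/c2cn(-c3ccccc3)nc2-c2cccnc2)c(OC)c1` share one core; compound 3 `COc1ccc(OC)c(C(=O)/C=C/c2cn(-c3ccccc3)nc2-c2ccncc2)c1` and the as yet unmeasured compound 4 `COc1ccc(C(=O)/C=C/c2cn(-c3ccccc3)nc2-c2ccncc2)c(OC)c1` share another. In a functional assay on HCT-116 cells (Homo sapiens) for inhibition, read by sulforhodamine B assay, with a stated time of 72 h (on this read-out higher numbers stand for weaker inhibition and lower numbers for stronger inhibition), compound 1 gives 1000 nM, compound 2 gives 1300 nM, and compound 3 gives 900 nM. The two cores differ by pyridin-4-yl in place of pyridin-3-yl on an aromatic carbon, and that difference gave a 1.1-fold lower number from compound 1 to compound 3 (0.05 log units; within the scatter). The change from compound 1 to compound 2 is 2,4-dimethoxyphenyl in place of 2,5-dimethoxyphenyl on a carbonyl carbon, which gave a 1.3-fold higher number from compound 1 to compound 2 (0.11 log units; within the scatter). Compound 4 differs from compound 3 by 2,4-dimethoxyphenyl in place of 2,5-dimethoxyphenyl on a carbonyl carbon, the same change at a place described in the same words, so it is taken as the same change made on the other core. The step from compound 3 to compound 4 is expected at a 1.3-fold higher number from compound 3 to compound 4 (0.12 log units; within the scatter), resting only on the step seen once before from compound 1 to compound 2 a 1.3-fold higher number from compound 1 to compound 2 (0.11 log units; within the scatter). One prior example is a thin basis, and since both measured steps lie within the scatter, a step anywhere inside the scatter would be consistent. Compound 4 is therefore estimated at 1200 nM in this assay, expected between 600 nM and 2400 nM.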

Compound 4, half-maximal inhibitory concentration: 4400 nM
For compound 4 the middle estimate is 3.7-fold (0.56 log units) below the measured one, outside the stated range (above it).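

In this assay, 2,4-dimethoxyphenyl in place of 2,5-dimethoxyphenyl on a carbonyl carbon gave a 4.9-fold higher number from compound 3 to compound 4 (0.69 log units; beyond the scatter), so the size of this change did not carry from one core to the other: the same change on two cores in this assay, a 1.3-fold higher number (0.11 log units; within the scatter) from compound 1 to compound 2 and a 4.9-fold higher number (0.69 log units; beyond the scatter) from compound 3 to compound 4, 3.8-fold (0.58 log units) apart, beyond the scatter of two such steps

Read along the other edge of the same set, pyridin-4-yl in place of pyridin-3-yl on an aromatic carbon gave a 3.4-fold higher number from compound 2 to compound 4 (0.53 log units; beyond the scatter), so that change also depended on its partner group: the same change on two cores in this assay, a 1.1-fold lower number (0.05 log units; within the scatter) from compound 1 to compound 3 and a 3.4-fold higher number (0.53 log units; beyond the scatter) from compound 2 to compound 4, 3.8-fold (0.58 log units) apart, beyond the scatter of two such steps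

Both comparisons rest on the same four compounds and form one observation of non-additivity, which shows that a step read on one core is an unsafe guide here but does not show how general this is or what causes it.

From the compounds shown here alone, it remains open whether the dependence persists with pyridin-2-yl in place of either pyridinyl group. Also open, going by these compounds, is how the steps behave when an amine or a carboxylic acid replaces one methoxy group on the dimethoxyphenyl group.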